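Swapping the Sulfur Substituent: Compound 2 to Compound 4

The source may hold more compounds than are shown below. What is called first, only, known or untested is meant among the compounds shown, and "the series" means these compounds.

Measured so far in a functional assay on A-375 cells (Homo sapiens) for inhibition, read by CCK-8 assay, with a stated time of 72 h, tested at 2 uM; a lower number here means less inhibition of growth, a higher number more inhibition of growth at the concentration tested
- compound 1 `Nc1ccccc1NC(=O)/C=C/c1ccc(CSc2ccc(Cl)cc2)cc1` gives 13.4%
- compound 2 `Nc1ccccc1NC(=O)/C=C/c1ccc(CSc2cccc(F)c2)cc1` gives 6.75%
- compound 3 `Nc1ccccc1NC(=O)c1ccc(CSc2cccc(F)c2)cc1` gives 37.7%

Compound 2 lies within the scatter of compound 1, and compound 3 reads clearly higher than both. Compound 4 `Cc1ccc(SCc2ccc(/C=C/C(=O)Nc3ccccc3N)cc2)cc1` has not been measured. It differs from compound 2 as follows: 4-methylphenyl in place of 3-fluorophenyl on a sulfur. That is, 4-methylphenyl sits in place of 3-fluorophenyl on a sulfur. One measured step swaps the group at this same place: a number 6.7 percentage points lower from compound 1 to compound 2 (within the scatter). Compound 3 differs elsewhere, so it says little here. Going by the values given here, with only that small step as a guide, the expected change is a number 3.3 percentage points higher from compound 2 to compound 4 (within the scatter), nothing beyond the scatter. For compound 4 the estimated value is 10%, with an expected range from 2% to 22%.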

Compound 4, percent growth inhibition at one concentration: 22.9%
Compound 4: the middle estimate sits 12.9 percentage points below what was measured, outside the stated range (above it).
By their numbers in this assay, from the lowest: compounds 2, 1 and 4 (each within the scatter of the next, the first and the last beyond it); then compound 3.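

In this assay, the group on the sulfur can shift the reading beyond the scatter, which the earlier swap at this place did not do: 4-methylphenyl in place of 3-fluorophenyl gives a clear step (a number 16.2 percentage points higher from compound 2 to compound 4 (beyond the scatter)). Methyl in place of chloro on an aromatic carbon does not separate the two compounds (a number 9.5 percentage points higher from compound 1 to compound 4 (within the scatter)). Nothing available explains the step from 3-fluorophenyl to 4-methylphenyl. From the compounds shown here alone, how an amine or a carboxylic acid on this ring would read remains open. So does whether 4-methylphenyl would act the same way on the core of compound 3.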